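A few compounds are considered here, and "the series" means these few. Any claim that something is new, unique, unknown or untested is made for them only; others in the source may bear on it.

Measured so far:
compound 1 `CC(C)C1CC(=O)N(c2ccccc2C(=O)OCC2CCCN(CCCc3ccccc3)C2)C1=O` — 2500 nM
compound 2 `O=C(OCC1CCCN(CCCc2ccccc2)C1)c1ccccc1N1C(=O)CC(C2CCCC2)C1=O` — 1200 nM
compound 3 `O=C(OCC1CCCN(CCCc2ccccc2)C1)c1ccccc1N1C(=O)CC(Cc2ccccc2)C1=O` — 1300 nM

In a functional assay with Neuronal acetylcholine receptor; alpha3/beta4 (Homo sapiens) as the target (on this read-out lower numbers stand for stronger inhibition and higher numbers for weaker inhibition), compound 1 gives the highest number of the three. The step of a 2.1-fold lower number from compound 1 to compound 2 (0.32 log units; beyond the scatter) was modest; the steps of a 1.9-fold lower number from compound 1 to compound 3 (0.28 log units; within the scatter) and a 1.1-fold higher number from compound 2 to compound 3 (0.03 log units; within the scatter) stay within the scatter. Compound 4 `O=C(OCC1CCCN(CCCc2ccccc2)C1)c1ccccc1F` differs from compound 1 by one fluorine atom in place of a group of 10 heavy atoms (7 carbon, 1 nitrogen, 2 oxygen; one five-membered non-aromatic ring with 1 hetero atom), on an aromatic carbon. Among the compounds with values here, none of the measured steps bears directly on this change: each of them only swaps the substituent on a saturated ring carbon of the group that now leaves, and all three were small. Removal of the whole group is untested, so a step in this assay in either direction is possible; a weaker result is taken as the more likely outcome, with wide bounds. Compound 4 is expected to give about 5000 nM (range 1000 nM to 25000 nM). The expected step is therefore a 2.0-fold higher number from compound 1 to compound 4 (0.30 log units; within the scatter).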

Compound 4, half-maximal inhibitory concentration: 5200 nM
Beside the measured number, compound 4's estimate is 1.0-fold (0.02 log units) below it, within the range that was stated.
By their numbers in this assay, from the lowest: compounds 2, 3 and 1 (each within the scatter of the next, the first and the last beyond it); then compound 4.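

In this assay, within the data shown here, fluoro in place of the whole group on the aromatic carbon gives a 2.1-fold higher number from compound 1 to compound 4 (0.32 log units; beyond the scatter) and a 4.3-fold higher number from compound 2 to compound 4 (0.64 log units; beyond the scatter) as modest steps, the first change at this aromatic carbon itself rather than on a saturated ring carbon of the group. Compound 4 still gives a measured number without the group, so the group is not required for inhibition here. No available evidence explains these steps. From the compounds shown here alone, what an amine, a carboxylic acid or a methoxy group would give on this aromatic carbon stays open. Which part of the departed group accounts for the difference also stays open.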